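This account rests on a few compounds, and the source may have more. Where it says the series, first, only, none or still open, it means among the compounds named here.

Three members of the series have so far been measured in a functional assay on HeLa cells (Homo sapiens) for antiproliferative activity, read by MTT assay, with a stated time of 48 h; a lower number here means a stronger inhibitor, a higher number a weaker inhibitor. Compound 1 `Oc1ccc2c(c1)CCc1ccc(O)c(c1)Oc1ccc(cc1)CCc1cccc(O)c1O2` gives 15900 nM in this assay. Compound 2 `Oc1ccc2c(c1)CCc1ccc(O)c(c1)Oc1ccc(cc1O)CCc1cccc(O)c1O2` carries hydroxy in place of hydrogen on an aromatic carbon relative to compound 1; in this assay compound 2 gives 26800 nM, and that change made a 1.7-fold higher number from compound 1 to compound 2 (0.23 log units; within the scatter). Compound 3 `Oc1ccc2cc1Oc1ccc(cc1)CCc1ccc(O)c(c1)Oc1ccc(cc1)CC2` rests on another core; how the core of compound 3 differs from the core of compound 1 is not broken down here. In this assay compound 3 gives 22700 nM, and this number sits within the scatter of the numbers of both compound 1 and compound 2. Compound 4 `Oc1ccc2cc1Oc1ccc(cc1)CCc1ccc(O)c(c1)Oc1ccc(cc1O)CC2` is not yet measured in this assay. For the measured compounds named here, it differs from compound 3 by hydroxy in place of hydrogen on an aromatic carbon, the same change, at a place described in the same words, as the one between compound 1 and compound 2. For compound 4 a step of about a 1.3-fold higher number from compound 3 to compound 4 (0.12 log units; within the scatter) is expected because a 1.7-fold higher number from compound 1 to compound 2 (0.23 log units; within the scatter) was small on the other core. Compound 4 is therefore estimated at 30000 nM in this assay, with a likely range from 14000 nM to 65000 nM.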

Compound 4, half-maximal inhibitory concentration: 29500 nM
Compound 4: middle estimate off by 1.0-fold (0.01 log units), on the high side; the measured number falls inside the stated range.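

Hydroxy in place of hydrogen on an aromatic carbon has now been read on two cores in this assay, and the new reading is a 1.3-fold higher number from compound 3 to compound 4 (0.11 log units; within the scatter). Set side by side, the two readings do not differ beyond what repeated measurements would give: the same change on two cores in this assay, a 1.7-fold higher number (0.23 log units; within the scatter) from compound 1 to compound 2 and a 1.3-fold higher number (0.11 log units; within the scatter) from compound 3 to compound 4, 1.3-fold (0.11 log units) apart, within the scatter of two such steps. The change therefore stays within the scatter on both the core of compound 1 and the core of compound 3 in this assay, but this does not show a real difference within either pair, and two pairs on two cores say nothing about how the change would read on any further core.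

The compounds shown leave open whether another group on the same aromatic carbon, such as methoxy, fluorine, an amine or a carboxylic acid, would give a step beyond the scatter. They also leave open whether hydroxy on a different aromatic carbon of these cores would read the same way.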